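The source may hold more compounds than are shown below. What is called first, only, known or untested is meant among the compounds shown, and "the series" means these compounds.

Compound 1 `COc1cc2cc(Oc3ccc(NC(=O)Nc4ccccc4)cc3)c(C)nc2cc1OC` is the weakest of the three measured compounds: in a functional assay on HOP-62 cells (Homo sapiens) for inhibition, read by sulforhodamine B assay, with a stated time of 48 h, tested at 10 uM (on this read-out lower numbers stand for a stronger effect and higher numbers for a weaker effect at the one concentration tested), compound 1 gives 103%, the highest number shown. Compound 2 `COc1cc2cc(Oc3ccc(NC(=O)Nc4ccc(C)cc4)cc3)c(C)nc2cc1OC` gives 66.9% and compound 3 `COc1cc2cc(Oc3ccc(NC(=O)Nc4cccc(C(F)(F)F)c4)cc3)c(C)nc2cc1OC` gives 25%. The measured steps all run downward: a number 36.1 percentage points lower from compound 1 to compound 2 (beyond the scatter), a number 78 percentage points lower from compound 1 to compound 3 (beyond the scatter) and a number 41.9 percentage points lower from compound 2 to compound 3 (beyond the scatter). Compound 4 `COc1cc2cc(Oc3ccc(NC(=O)Nc4ccc(Cl)c(C(F)(F)F)c4)cc3)c(C)nc2cc1OC` is built from compound 1 by one change: 4-chloro-3-(trifluoromethyl)phenyl in place of phenyl on an amide-type nitrogen. The step from compound 1 to compound 3, which also brought in trifluoromethyl, bears most directly on this change, and the step from compound 2 to compound 3 points the same way. A large downward step is therefore expected, a number 83 percentage points lower from compound 1 to compound 4 (beyond the scatter), and compound 4 is estimated at 20%, within a range from 5% to 45%.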

Compound 4, a percentage reported as activity, at one concentration (the size of the read-out at that concentration, not a potency): -51%
For compound 4 the middle estimate is 71 percentage points above the measured one; the measured number lies below the stated range.
By their numbers in this assay, from the lowest: compound 4; then compound 3; then compound 2; then compound 1.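

With chloro in place of hydrogen on the ring that already carries trifluoromethyl, this assay gives a number 76 percentage points lower from compound 3 to compound 4 (beyond the scatter), so trifluoromethyl alone had not exhausted what this ring on the amide-type nitrogen can do. The full change gives a number 154 percentage points lower from compound 1 to compound 4 (beyond the scatter), and replacing 4-methylphenyl gives a number 117.9 percentage points lower from compound 2 to compound 4 (beyond the scatter), with only compound 4 reaching a negative number, -51%. Nothing shown here accounts for the size of these steps. Still open, as far as these compounds go, is how a ring carrying chloro without trifluoromethyl would read, and how a nitrile or an amine would read on this ring.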